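Swapping the aryl amide on a piperidine sulfonamide

A few compounds are considered here, and "the series" means these few. Any claim that something is new, unique, unknown or untested is made for them only; others in the source may bear on it.

Measured so far:
- compound 1 `COC(=O)c1cccc(C(=O)N2CCC(N(C3CC3)S(=O)(=O)c3cccc(C(F)(F)F)c3)CC2)c1` — in an assay on cells for inhibition of Voltage-dependent L-type calcium channel subunit alpha-1C (Homo sapiens), read by FLIPR and calcium flux, tested at 3 uM (a lower number here means a weaker effect, a higher number a stronger effect of the compound at the concentration tested), compound 1 gives "not determined" (no result reported)
- compound 2 `O=C(c1ccc(OC(F)(F)F)cc1)N1CCC(N(C2CC2)S(=O)(=O)c2cccc(C(F)(F)F)c2)CC1` — 88%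

For the measured compounds named here, compound 2 gives 88% in this assay, the only number in hand, so nothing can be compared with it yet. Compound 3 `CS(=O)(=O)c1ccc(F)cc1C(=O)N1CCC(N(C2CC2)S(=O)(=O)c2cccc(C(F)(F)F)c2)CC1` changes one group, (5-fluoro-2-(methylsulfonyl)phenyl in place of 4-(trifluoromethoxy)phenyl on a carbonyl carbon). Going by the values given here, no measured pair shows what such a change does here, so the expectation rests on compound 2 alone. A modest drop, just beyond the scatter, is expected, a number 23 percentage points lower from compound 2 to compound 3 (beyond the scatter). Compound 3 is estimated at 65%, within 35% to 90%.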

Compound 3, a percentage reported as inhibition, at one concentration (the size of the read-out at that concentration, not a potency): 34%
For compound 3 the middle estimate is 31 percentage points above the measured one; the whole stated range lies above it.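

On the carbonyl carbon bonded to the ring amide nitrogen, replacing 4-(trifluoromethoxy)phenyl with 5-fluoro-2-(methylsulfonyl)phenyl gives a number 54 percentage points lower from compound 2 to compound 3 (beyond the scatter) in this assay. This shows that the read-out at this position depends strongly on which substituted phenyl is present, even though both groups hold 11 heavy atoms. No measurement shown here accounts for the drop. Still open, on these data alone, is whether the fluorine, the methylsulfonyl or the two together carry the change, and how a phenyl bearing an amine or a carboxylic acid would read out.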